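Aryl replacement on the shared core: outlook for compound 3

A few compounds are considered here, and "the series" means these few. Any claim that something is new, unique, unknown or untested is made for them only; others in the source may bear on it.

Compound 2 `Cc1nn(-c2nc(-c3ccc(Cl)c(Cl)c3)c(SC(C)C)s2)c(C(=O)O)c1-c1cccnc1` stands at the high end of the two numbers in hand: in a functional assay on BJAB cells (Homo sapiens) for antiproliferative activity, with a stated time of 4 days (a higher number here means that more compound is needed for the effect, a lower number that less compound is needed), compound 2 gives 12000 nM, whereas compound 1 `COc1cc(-c2c(C)nn(-c3nc(-c4ccc(Cl)c(Cl)c4)c(SC(C)C)s3)c2C(=O)O)cc(C(F)(F)F)c1` gives 1380 nM in this assay. For the measured compounds named here, the only measured step between them, an 8.7-fold higher number from compound 1 to compound 2 (0.94 log units; beyond the scatter), is the sole reference point for the change now considered.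

Compound 3 `COc1cc(Cl)cc(-c2c(C)nn(-c3nc(-c4ccc(Cl)c(Cl)c4)c(SC(C)C)s3)c2C(=O)O)c1` is not yet measured. It differs from compound 2 by 3-chloro-5-methoxyphenyl in place of pyridin-3-yl on an aromatic carbon. This change removes the group whose introduction in the step from compound 1 to compound 2 raised the number, and brings in a phenyl carrying a methoxy group, as compound 1 also carries. Going by the values given here, the relevant comparison is therefore the step of an 8.7-fold higher number from compound 1 to compound 2 (0.94 log units; beyond the scatter), run in reverse: a decrease of roughly that size in this assay is expected for compound 3, because the only measured step, an 8.7-fold higher number from compound 1 to compound 2 (0.94 log units; beyond the scatter), points that way. The estimated step for compound 3 is an 8.0-fold lower number from compound 2 to compound 3 (0.90 log units; beyond the scatter). Compound 3 is expected to give about 1500 nM in this assay, with a likely range from 500 nM to 4500 nM.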

Compound 3, half-maximal effective concentration: 760 nM
Compound 3: the middle estimate sits 2.0-fold (0.30 log units) above what was measured; low and high end bracket the measured number.
By their numbers in this assay, from the lowest: compounds 3 and 1 (each within the scatter of the next); then compound 2.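

At this position, the aromatic carbon of the five-membered ring that lies next to the ring atom bearing the carboxy group, pyridin-3-yl now has two phenyl comparators: in this assay, replacing it with 3-chloro-5-methoxyphenyl gives a 16-fold lower number from compound 2 to compound 3 (1.20 log units; beyond the scatter), in the same direction as the reverse of the earlier step. For the compounds shown here, exchanging trifluoromethyl for chloro on the phenyl gives a 1.8-fold lower number from compound 1 to compound 3 (0.26 log units; within the scatter), so these two substituents are not separated in this read-out, and both methoxy-bearing phenyls give lower numbers than pyridin-3-yl, with no compound among the three going against that. Nothing shown bears on why the numbers fall as they do.

The three compounds leave open whether the difference from pyridin-3-yl goes with the ring nitrogen, the methoxy group, the second phenyl substituent or their combination, since an unsubstituted phenyl and a phenyl carrying methoxy alone are not among them. On these data alone, it also remains open whether the tolerance seen for chloro and trifluoromethyl extends to other groups at that place, such as a nitrile or an amine.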